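This account rests on a few compounds, and the source may have more. Where it says the series, first, only, none or still open, it means among the compounds named here.

Of the compounds shown here, three built on one shared core have been tested in an assay on microsomes from brain for inhibition of Fatty-acid amide hydrolase 1 (Rattus norvegicus), read by fluorescence and HPLC, with a stated time of 60 min; a higher number here means a weaker inhibitor, a lower number a stronger inhibitor. Compound 1 `CCCCCCCCc1ccc(OCC(=O)Cn2nnc(-c3ccccc3)n2)cc1` gives 24 nM in this assay, and compound 2 `CCCCCCCCc1ccc(OCC(=O)Cn2nnc(-c3cccc(S(=O)(=O)N(C)C)c3)n2)cc1` gives 420 nM. Going by the values given here, the one single-point comparison among the measured compounds is an 18-fold higher number from compound 1 to compound 2 (1.24 log units; beyond the scatter), a loss of potency placed on a ring other than the one altered below. Compound 3 `CCCCCCCCc1ccc(OCC(=O)Cn2nnnc2SC)cc1` gives 22 nM. Its number is the lowest of the three, yet the gap to compound 1 is within the usual scatter, so those two cannot be told apart; only compound 2 stands clearly apart from it.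

The next compound, compound 4 `CCCCCCCCc1ccc(OCC(=O)Cn2nnnc2C(=O)OC)cc1`, differs from compound 3 by methoxycarbonyl in place of methylsulfanyl on an aromatic carbon. Among the compounds with values here, no measured step alters a group at this place, so the step between compound 1 and compound 2, though large, bears on it only loosely. What the numbers do show is that compound 1 and compound 3, which carry different groups on the five-membered ring, sit within the scatter of each other. On that basis the change is expected to produce a 1.8-fold higher number from compound 3 to compound 4 (0.26 log units; within the scatter), a shift of modest size at most. Compound 4 is therefore estimated at 40 nM in this assay, within a range from 12 nM to 150 nM.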

Compound 4, half-maximal inhibitory concentration: 1000 nM
Compound 4: middle estimate off by 25-fold (1.40 log units), on the low side, and the stated range ends below it.
By their numbers in this assay, from the lowest: compounds 3 and 1 (each within the scatter of the next); then compound 2; then compound 4.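

In this assay the change from methylsulfanyl to methoxycarbonyl on the aromatic carbon between two ring nitrogen atoms gives a 45-fold higher number from compound 3 to compound 4 (1.66 log units; beyond the scatter) and marks the first measured sign that this position is sensitive to which group it carries. The step is beyond the usual scatter and large, so the identity of this one substituent can strongly change the measured inhibition while the rest of the molecule stays the same. The incoming group differs from the outgoing one in several ways at once, with 4 heavy atoms instead of 2, 2 hydrogen-bond acceptors instead of 1, and a double bond outside aromatic rings, and no measurement available here explains the loss of potency.

The compounds shown leave open which of those differences accounts for the step, since this single pair changes them all together. A methyl or ethyl group, a carboxylic acid, or an amide on the same carbon would help show whether the loss follows the carbonyl, the oxygen atoms or simply the size of the group.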